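Adding a Third Methoxy Group to Compound 1

This account rests on a few compounds, and the source may have more. Where it says the series, first, only, none or still open, it means among the compounds named here.

Within the data shown here, compound 1 `COc1ccc(-c2cc(C(=O)/C=C/c3ccccc3)nc3cc(-c4ccccc4)nn23)cc1OC` gives 15600 nM in a functional assay on DU-145 cells (Homo sapiens) for antiproliferative activity, read by MTT assay, with a stated time of 24 h (on this read-out lower numbers stand for stronger inhibition and higher numbers for weaker inhibition), the lowest of the two numbers measured so far, though only narrowly. Among the measured compounds shown here, its nearest neighbour, compound 2 `COc1ccc(-c2cc(C(=O)/C=C/c3ccc(Cl)cc3)nc3cc(-c4ccccc4)nn23)cc1OC`, gives 22400 nM in this assay, and the step of a 1.4-fold higher number from compound 1 to compound 2 (0.16 log units; within the scatter) is the only measured comparison available. Compound 3 `COc1cc(-c2cc(C(=O)/C=C/c3ccccc3)nc3cc(-c4ccccc4)nn23)cc(OC)c1OC` differs from compound 1 by methoxy in place of hydrogen on an aromatic carbon; cut one bond further out, this reads as 3,4-dimethoxyphenyl to 3,4,5-trimethoxyphenyl. For the measured compounds named here, the one measured step concerns a chloro group on the other aromatic ring, so no measured step bears directly on adding a methoxy group here, and the single step that exists stayed within the scatter. On that basis compound 3 is expected to give 12000 nM, with a range from 4000 nM to 35000 nM. The expected step is a 1.3-fold lower number from compound 1 to compound 3 (0.11 log units; within the scatter), not clearly beyond the scatter.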

Compound 3, half-maximal inhibitory concentration: 16300 nM
The estimate for compound 3 lay 1.4-fold (0.13 log units) below the measured number; measured number inside the range.
By their numbers in this assay, from the lowest: compounds 1, 3 and 2 (each within the scatter of the next).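

In this assay, methoxy in place of hydrogen on this aromatic carbon, which turns 3,4-dimethoxyphenyl into 3,4,5-trimethoxyphenyl, gives a 1.0-fold higher number from compound 1 to compound 3 (0.02 log units; within the scatter) and so cannot be told apart from the parent compound. Among these compounds, this is the first measured step on this ring, as the earlier step concerned a chloro group on the other aromatic ring, and it shows that this position accepts a methoxy group ortho to an existing methoxy group without a change beyond the scatter. No available evidence accounts for this result.

The compounds shown leave open whether an amine or a carboxylic acid on this same carbon, or a longer chain such as propoxy, would also stay within the scatter of compound 1. They also leave open how a chloro group on the other aromatic ring would read alongside 3,4,5-trimethoxyphenyl.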